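Hydroxyphenyl series: one 4-hydroxyphenyl for one 2-hydroxyphenyl

The compounds below may be only part of what the source reports. "The series", "measured", "known", "first", "only" and "open" are said of these compounds alone.

Compound 1 `Oc1ccc(-c2cc(-c3ccc(O)cc3)nc(-c3ccc(O)cc3)c2)cc1` gives 4270 nM in a functional assay on T47D cells (Homo sapiens) for cytotoxicity, read by CCK-8 assay, with a stated time of 4 days; a higher number here means a weaker inhibitor, a lower number a stronger inhibitor. Compound 2 `Oc1ccccc1-c1cc(-c2ccccc2O)nc(-c2ccccc2O)c1` gives 2510 nM in this assay, and compound 3 `Oc1ccc(-c2cc(-c3ccccc3O)cc(-c3ccc(O)cc3)n2)cc1` gives 5350 nM. Compound 4 `Oc1ccc(-c2cc(-c3ccccc3O)nc(-c3ccccc3O)c2)cc1` is not yet measured. The difference between the cores of compound 2 and compound 3 is not broken down here. The change 4-hydroxyphenyl in place of 2-hydroxyphenyl on an aromatic carbon is measured as a 1.3-fold lower number from compound 3 to compound 1 (0.10 log units; within the scatter). The change 4-hydroxyphenyl in place of 2-hydroxyphenyl on an aromatic carbon is the same kind of change, not the same: in compound 3 the place is meta to two 4-hydroxyphenyl groups, in compound 2 it is meta to two 2-hydroxyphenyl groups. Starting from compound 2, the step in this assay is expected to be a 1.3-fold lower number from compound 2 to compound 4 (0.10 log units; within the scatter), resting on the earlier step being within the scatter. Compound 4 is estimated at 2000 nM, between 1000 nM and 4500 nM.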

Compound 4, half-maximal inhibitory concentration: 18300 nM
For compound 4 the middle estimate is 9.2-fold (0.96 log units) below the measured one; measured number outside the range, above it.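

Within this assay, 4-hydroxyphenyl in place of 2-hydroxyphenyl opposite the ring nitrogen gives a 7.3-fold higher number from compound 2 to compound 4 (0.86 log units; beyond the scatter), making compound 4 a weaker inhibitor than compound 2. The size and direction of this change do not carry from one core to the other: the same change on two cores in this assay, a 1.3-fold lower number (0.10 log units; within the scatter) from compound 3 to compound 1 and a 7.3-fold higher number (0.86 log units; beyond the scatter) from compound 2 to compound 4, 9.1-fold (0.96 log units) apart, beyond the scatter of two such steps

This shows that the result of the change depends on the core, but with one pair per core it does not show which difference between the cores is responsible or how the change would behave on any further core. Open, on these data alone, is whether a methoxy group in place of the hydroxyl groups would show the same dependence on the core. Also open, as far as these compounds go, is how an amine or a carboxylic acid on the phenyl ring would behave at this place.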